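The source may hold more compounds than are shown below. What is called first, only, known or untested is meant among the compounds shown, and "the series" means these compounds.

Series notes, all tested in a functional assay on MDA-MB-435 cells (Homo sapiens) for cytotoxicity, read by MTT assay, with a stated time of 72 h; on this read-out higher numbers stand for weaker inhibition and lower numbers for stronger inhibition. Compound 1 `O=C(NCc1ccc(F)cc1)c1nc(Br)c2cccnc2c1NCc1ccccc1` carries a benzylamino group on the shared core. In this assay, within the data shown here, compound 1 gives only a limit, > 20000 nM, and that is where compound 1 stands on the numbers so far: the limit of > 20000 nM in this assay, at which 1 of the 3 values shown sits. Two other members carry a different group at the same position. Compound 2 `N[C@H]1CC[C@H](Nc2c(C(=O)NCc3cccc(C(F)(F)F)c3)nc(Br)c3cccnc23)CC1` gives 4200 nM in this assay. Compound 3 `CC(C)(C)OC(=O)N1CCN(c2c(C(=O)NCc3ccc(F)cc3)nc(Br)c3cccnc23)CC1` gives 10000 nM in this assay. Compound 4 `O=C(NCc1ccc(F)cc1)c1nc(Br)c2cccnc2c1NCCO` is not yet measured; it differs from compound 1 by hydroxymethyl in place of phenyl on a saturated chain carbon bound to a nitrogen on an aromatic ring, that is benzyl to 2-hydroxyethyl, benzylamino to (2-hydroxyethyl)amino. Among the measured compounds shown here, no measured pair differs in one place, so no step size is on record for this series. Since compound 2 reaches 4200 nM and compound 3 reaches 10000 nM with other groups in this place, a move to a readable value is conceivable. Starting from compound 1, whose value is only a limit, the size of any step cannot be fixed. The expectation is an at least 1.3-fold lower number from compound 1 to compound 4 (0.12 log units; that floor lies within the scatter), a shift of uncertain size, at most modest, toward stronger inhibition. For compound 4 in this assay the estimate is 15000 nM, between 5000 nM and 40000 nM, with a fair chance that only a limit is returned again.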

Compound 4, half-maximal inhibitory concentration: > 20000 nM
Compound 4: a limit, no number (the forecaster's own chance of this, stated with the estimate: 50%); at least 1.3-fold (0.12 log units) between middle value and limit.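

Compound 1 and compound 4 each return only a limit in this assay, so no step can be read from benzylamino to (2-hydroxyethyl)amino. The compounds shown leave open where either compound's actual value lies and whether this exchange changes inhibition at all.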